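The compounds below may be only part of what the source reports. "The series", "measured", "known", "first", "only" and "open" are said of these compounds alone.

Measured compounds in a functional assay on SF-295 cells (Homo sapiens) for inhibition, read by sulforhodamine B assay, with a stated time of 48 h; a lower number here means a stronger inhibitor of growth, a higher number a weaker inhibitor of growth:
- compound 1, `COc1ccc(CNc2nc3cc(N)cc(N)c3nc2-c2ccccc2)cc1OC` — compound 1 gives 13200 nM
- compound 2, `COc1cc(CNc2nc3cc(N)cc(N)c3nc2-c2ccccc2)cc(OC)c1OC` — compound 2 gives 1660 nM
- compound 3, `CCOC(=O)[C@H](CCC(=O)O)NC(=O)c1ccc(Oc2nc3cc(N)cc(N)c3nc2-c2ccccc2)cc1` — compound 3 gives 40700 nM

Compound 1 stands second highest of the three numbers in this assay. Its nearest neighbour is compound 3, whose number is higher and beyond the scatter; compound 2 lies furthest off, with a lower number, also beyond the scatter.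

Compound 4, `COc1ccc(CNc2nc3cc(N)cc(N)c3nc2-c2ccccc2)cc1`, is not yet measured. It differs from compound 1 in one place: hydrogen in place of methoxy on an aromatic carbon.

Going by the values given here, one measured step bears on this change. From compound 1 to compound 2 a methoxy was added to the same aromatic ring, and the number fell: an 8.0-fold lower number from compound 1 to compound 2 (0.90 log units; beyond the scatter). Compound 4 moves the other way, taking one methoxy off that ring. Nothing else in the set tests a methoxy removal, and compound 3 is too different to help. The expectation is therefore a higher number for compound 4 than for compound 1, modest in size, with considerable uncertainty since the two methoxy positions need not behave alike.

The expected step is a 2.3-fold higher number from compound 1 to compound 4 (0.36 log units; beyond the scatter). For compound 4 in this assay the estimate is 30000 nM, with a range from 10000 nM to 100000 nM.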

Compound 4, concentration for 50% growth inhibition: 17800 nM
Compound 4: middle estimate off by 1.7-fold (0.23 log units), on the high side; measured number inside the range.
By their numbers in this assay, from the lowest: compound 2; then compounds 1 and 4 (each within the scatter of the next); then compound 3.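

In this assay, hydrogen in place of methoxy on this aromatic carbon, ortho to a methoxy group and meta to a large group, gives a 1.3-fold higher number from compound 1 to compound 4 (0.13 log units; within the scatter), so compound 4 cannot be told apart from compound 1 in this read-out. Going by these compounds alone, the change from 3,4-dimethoxyphenyl to 4-methoxyphenyl therefore shows that this methoxy is not needed to hold the growth inhibition seen with compound 1, a point that the earlier compounds could not settle. The ring's substitution still matters in one direction, since the added methoxy gives an 8.0-fold lower number from compound 1 to compound 2 (0.90 log units; beyond the scatter), so a single methoxy step on this ring does not have one fixed size, and the two steps are not mirror images of each other.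

The compounds shown leave open whether a hydroxy group, a fluorine or a longer chain such as ethoxy at this position would also read the same as hydrogen and methoxy, and whether the remaining methoxy can give way to hydrogen as well. No measurement at hand accounts for the difference in size between the two steps.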